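Brominated diaryl ether series: benzyloxy to 3-bromopropoxy

The compounds below may be only part of what the source reports. "The series", "measured", "known", "first", "only" and "open" are said of these compounds alone.

Three members of the series have been measured in a functional assay on U-937 cells (Homo sapiens) for cytotoxicity, read by MTT assay, with a stated time of 24 h; a lower number here means a stronger inhibitor, a higher number a weaker inhibitor. Compound 1 `CC(C)(C)OC(=O)N1CCCN(CCCCCOc2c(Br)cc(Br)cc2Oc2ccc(Br)cc2Br)CC1` gives 39.5 ug/mL, compound 2 `COc1ccccc1N1CCN(CCCCCOc2c(Br)cc(Br)cc2Oc2ccc(Br)cc2Br)CC1` gives 37.5 ug/mL, and compound 3 `Brc1ccc(Oc2cc(Br)cc(Br)c2OCc2ccccc2)c(Br)c1` gives 29 ug/mL. Compound 3 thus carries the lowest of the three numbers, but its gaps to compound 2 and to compound 1 both lie within the scatter, so no order among the three can be read. For the measured compounds named here, no pair of measured compounds differs in a single place, so no measured step is available. Compound 4 `BrCCCOc1c(Br)cc(Br)cc1Oc1ccc(Br)cc1Br` differs from compound 3 by 2-bromoethyl in place of phenyl on a saturated chain carbon bound to an oxygen on an aromatic ring. Going by the values given here, with no step to lean on, a change no larger than the scatter, in either direction, is expected for a 1.0-fold higher number from compound 3 to compound 4 (0.01 log units; within the scatter). Compound 4 is therefore estimated at 30 ug/mL, with a range from 15 ug/mL to 60 ug/mL.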

Compound 4, half-maximal inhibitory concentration: 30.3 ug/mL
Compound 4: the middle estimate sits 1.0-fold (0.00 log units) below what was measured; the measured number falls inside the stated range.
By their numbers in this assay, from the lowest: compounds 3, 4, 2 and 1 (each within the scatter of the next).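

At the saturated chain carbon bound to an oxygen on an aromatic ring, 2-bromoethyl in place of phenyl gives a 1.0-fold higher number from compound 3 to compound 4 (0.02 log units; within the scatter) in this assay. This first measured step in the series shows that, at this place, a group with no ring and fewer heavy atoms reads the same as phenyl within the scatter. No supporting measurement bears on this result. Going by these compounds, whether an amine or a carboxylic acid at this place would give a number beyond the scatter remains open. Also open, on these data alone, is how a plain propyl group, without the bromine, would read.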